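The source may hold more compounds than are shown below. What is called first, only, known or untested is meant among the compounds shown, and "the series" means these compounds.

Measured so far: compound 1 `CCCC(=O)OCCCCOC(=O)c1ccc(C(=O)Nc2ccc3c(c2)C(C)(C)CCC3(C)C)cc1` with 92600 nM in a functional assay on K562 cells (Homo sapiens) for inhibition, read by MTT assay, with a stated time of 48 h; a lower number here means a stronger inhibitor, a higher number a weaker inhibitor; compound 2 `Cc1cc2c(cc1C(=O)c1ccc(C(=O)OCCCOC(=O)c3ccc(C(=O)Nc4ccc5c(c4)C(C)(C)CCC5(C)C)cc3)cc1)C(C)(C)CCC2(C)C`, which in this assay gives 49100 nM.

Compound 1 holds the higher of the two numbers, but its gap to compound 2 lies within the scatter, so the two are not told apart. Compound 3 `CCCC(CCC)C(=O)OCCOC(=O)c1ccc(C(=O)Nc2ccc3c(c2)C(C)(C)CCC3(C)C)cc1` is not yet measured. It differs from compound 1 by ((1-propylbutyl)carbonyl)oxy in place of 2-((propylcarbonyl)oxy)ethyl on a saturated chain carbon, two bonds along the chain from an oxygen next to a carbonyl group. Going by the values given here, with no measured step of this kind, nothing beyond the scatter is expected in this assay: the step from compound 1 to compound 3 is estimated at a 1.2-fold lower number from compound 1 to compound 3 (0.06 log units; within the scatter). Compound 3 is thus expected at 80000 nM, within 30000 nM to 200000 nM.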

Compound 3, half-maximal inhibitory concentration: 664000 nM
Beside the measured number, compound 3's estimate is 8.3-fold (0.92 log units) below it; the measured number lies above the stated range.
By their numbers in this assay, from the lowest: compounds 2 and 1 (each within the scatter of the next); then compound 3.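

In this assay, going by these compounds alone, this is the first step that can be read at a single position, and it is not neutral: ((1-propylbutyl)carbonyl)oxy in place of 2-((propylcarbonyl)oxy)ethyl gives a 7.2-fold higher number from compound 1 to compound 3 (0.86 log units; beyond the scatter). This position on the saturated chain carbon therefore responds to the change, here towards a weaker inhibitor. Nothing available explains the shift.

One step cannot separate the effect of the 1-propylbutyl end from that of the chain carrying it. As far as these compounds go, how an amine or a carboxylic acid would read at this position remains open.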